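The source may report more compounds than this note shows. Statements on the series, on what has been measured and on what is new or still open speak of the compounds shown alone.

Measured so far: compound 1 `COc1cc(C(F)(F)F)cc(SC)c1C(=O)NC1(c2ccccc2)CCCN(C)C1`, 24 nM; compound 2 `COc1cccc(C2(NC(=O)c3c(OC)cc(C(F)(F)F)cc3SC)CCCN(C)C2)c1`, 110 nM.

Among the measured compounds shown here, in an assay on cells for inhibition of sodium- and chloride-dependent glycine transporter 1 (Homo sapiens) (a higher number here means that more compound is needed for the effect, a lower number that less compound is needed), compound 2 gives the highest of the two numbers measured; its nearest neighbour is compound 1, whose value is lower by a 4.6-fold higher number from compound 1 to compound 2 (0.66 log units; beyond the scatter), the only step recorded, which comes from a methoxy in place of hydrogen on an aromatic carbon.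

Compound 3 `COc1cc(C(F)(F)F)cc(SC)c1C(=O)NC1(c2ccncn2)CCCN(C)C1` differs from compound 2 by pyrimidin-4-yl in place of 3-methoxyphenyl on a saturated ring carbon. For the measured compounds named here, no measured step touches this kind of exchange: the one step known only shows that the group on this saturated ring carbon can move the number by a modest amount. The direction for an aromatic ring with two nitrogen atoms in place of a methoxy-bearing ring of carbon is therefore open, and the expectation for compound 3 is a step of a 1.4-fold lower number from compound 2 to compound 3 (0.14 log units; within the scatter) with wide uncertainty. Compound 3 is accordingly estimated at 80 nM, within a range from 20 nM to 320 nM.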

Compound 3, half-maximal effective concentration: 1700 nM
The estimate for compound 3 lay 21-fold (1.33 log units) below the measured number; measured number above the stated range.
By their numbers in this assay, from the lowest: compound 1; then compound 2; then compound 3.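

In this assay the group on this saturated ring carbon proves able to move the number much further than the earlier pair showed: the exchange of an all-carbon aromatic ring for pyrimidin-4-yl gives a 15-fold higher number from compound 2 to compound 3 (1.19 log units; beyond the scatter) and also a 71-fold higher number from compound 1 to compound 3 (1.85 log units; beyond the scatter). Both steps exceed the modest 4.6-fold higher number from compound 1 to compound 2 (0.66 log units; beyond the scatter), so among these three groups pyrimidin-4-yl is the least tolerated, whichever carbon ring it replaces. Nothing available bears on the reason for this loss.

The compounds shown leave open whether both ring nitrogen atoms are needed for the loss, which a pyridinyl group with a single ring nitrogen would address. They also leave open how a saturated cyclohexyl group, or a phenyl ring carrying fluorine in place of methoxy, would behave at this carbon.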